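A few compounds are considered here, and "the series" means these few. Any claim that something is new, unique, unknown or untested is made for them only; others in the source may bear on it.

Measured so far in a functional assay on HeLa cells (Homo sapiens) for antiproliferative activity, read by MTT assay, with a stated time of 48 h; a higher number here means a weaker inhibitor, a lower number a stronger inhibitor:
compound 1 `Cc1ccc2nc(Nc3nc(Nc4ccc(S(N)(=O)=O)cc4)ncc3F)sc2c1`: 1890 nM
compound 2 `Cc1ccc2nc(Nc3nc(Nc4ccc(S(C)(=O)=O)cc4)ncc3F)sc2c1`: 17200 nM
compound 3 `Cc1cnc(Nc2ccc(S(N)(=O)=O)cc2)nc1Nc1nc2ccccc2s1`: 2800 nM

Among these three, compound 2 stands at the highest number, and the gaps to compound 1 and to compound 3 both lie beyond the scatter. Compound 4 `COc1ccc2nc(Nc3nc(Nc4ccc(S(C)(=O)=O)cc4)ncc3F)sc2c1` differs from compound 2 in one place: methoxy in place of methyl on an aromatic carbon. Among the compounds with values here, no measured step touches this position. Within the data shown here, the only step available, a 9.1-fold higher number from compound 1 to compound 2 (0.96 log units; beyond the scatter), concerns the sulfonyl group, not the fused ring, so it gives no direct guide here. Among the measured compounds shown here, with no step bearing on the change, no movement beyond the scatter is expected in this assay. Compound 4 is therefore estimated at 17000 nM, with a range from 6000 nM to 50000 nM. This amounts to an expected 1.0-fold lower number from compound 2 to compound 4 (0.01 log units; within the scatter).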

Compound 4, half-maximal inhibitory concentration: 25400 nM
For compound 4 the middle estimate is 1.5-fold (0.17 log units) below the measured one; the range from low to high includes it.
By their numbers in this assay, from the lowest: compounds 1 and 3 (each within the scatter of the next); then compounds 2 and 4 (each within the scatter of the next).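

In this assay, within the data shown here, methoxy in place of methyl on this aromatic carbon gives a 1.5-fold higher number from compound 2 to compound 4 (0.17 log units; within the scatter) and so offers the first reading at this position of the fused rings. With the methyl on the sulfonyl sulfur, this swap, which adds one oxygen, leaves the number unmoved beyond the scatter. No measurement here accounts for this result. From the compounds shown here alone, whether the swap would read the same with the amino on the sulfonyl sulfur, as in compound 1, remains open. So does the effect of an amine or a carboxylic acid on this carbon.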